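This account rests on a few compounds, and the source may have more. Where it says the series, first, only, none or still open, it means among the compounds named here.

Compounds measured:
Compound 1 `CCOc1cc(=O)n(CCCO)c2c1CC(CC=C(C)C)C(C)(C)C2` gives 16.6% in a functional assay on PANC-1 cells (Homo sapiens) for inhibition, read by MTT assay, with a stated time of 24 h, tested at 10 uM; a lower number here means less inhibition, a higher number more inhibition at the concentration tested (going by the name of the read-out).
Compound 2 `CCOc1cc(=O)n(CCCO)c2c1CC(C/C=C(\C)CCC=C(C)C)C(C)(C)C2` gives 0.8% in this assay.
Compound 3 `COc1ccc(C(=O)NCCCOc2cc(=O)n(CCCO)c3c2CC(C/C=C(\C)CCC=C(C)C)C(C)(C)C3)cc1` gives 14.1% in this assay.

Compound 2 stands lowest of the three numbers in this assay; compound 3 is nearest and compound 1 furthest, and both gaps lie beyond the scatter. Among the compounds with values here, two measured steps touch compound 2: a number 15.8 percentage points lower from compound 1 to compound 2 (beyond the scatter), and a number 13.3 percentage points higher from compound 2 to compound 3 (beyond the scatter).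

Compound 4 `COc1ccc(NC(=O)Oc2cc(=O)n(CCCO)c3c2CC(C/C=C(\C)CCC=C(C)C)C(C)(C)C3)cc1` has not yet been measured in this assay. It differs from compound 2 in one place:
(4-methoxyphenyl)carbamoyl in place of ethyl on an oxygen on an aromatic ring
Within the data shown here, of the measured steps, the one from compound 2 to compound 3 bears most on this change, since there too a group built around a 4-methoxyphenyl and a carbonyl bound to nitrogen was added on the side of the oxygen on the aromatic ring, and the number rose modestly. The step from compound 1 to compound 2 concerns the other side of the core and bears little on it.

Compound 4 is therefore expected to show a modest rise in this assay, with an estimated step of a number 11.2 percentage points higher from compound 2 to compound 4 (beyond the scatter). The value expected for compound 4 is 12%, within the range 0% to 28%.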

Compound 4, a percentage reported as inhibition, at one concentration (the size of the read-out at that concentration, not a potency): 0%
Beside the measured number, compound 4's estimate is 12 percentage points above it; low and high end bracket the measured number.
By their numbers in this assay, from the lowest: compounds 4 and 2 (each within the scatter of the next); then compounds 3 and 1 (each within the scatter of the next).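

In this assay, putting (4-methoxyphenyl)carbamoyl in place of ethyl on an oxygen on an aromatic ring gives a number 0.8 percentage points lower from compound 2 to compound 4 (within the scatter), so the read-out does not separate the two compounds even though the entering group brings 11 heavy atoms, a six-membered aromatic ring and a hydrogen-bond donor. The earlier step, a number 13.3 percentage points higher from compound 2 to compound 3 (beyond the scatter), had shown a change beyond the scatter with a 4-methoxyphenyl and a carbonyl bound to nitrogen on that side of the core, and the new result shows that these parts do not bring such a change in every arrangement: here they are joined directly to the oxygen as a carbamoyl, and compound 4 gives 0%. Nothing available here accounts for the difference between these two outcomes.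

The compounds shown leave open whether a different group on this oxygen, such as a chain ending in an amine or a carboxylic acid, would move the number beyond the scatter. They also leave open how the (4-methoxyphenyl)carbamoyl group would behave on the core of compound 1, with its shorter 3-methylbut-2-en-1-yl side chain.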